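Methoxy to ethoxy on compound 2

This account rests on a few compounds, and the source may have more. Where it says the series, first, only, none or still open, it means among the compounds named here.

Within the data shown here, in a functional assay on MCF7 cells (Homo sapiens) for antiproliferative activity, read by MTT assay, with a stated time of 72 h (a higher number here means a weaker inhibitor, a lower number a stronger inhibitor), compound 2 (`COc1ccc(-c2ncnn2-c2cc(OC)c(OC)c(OC)c2)cc1`) gives 360 nM, the only number so far. Compound 1 (`COc1cc(-c2ncnn2-c2cccc(N)c2)cc(OC)c1OC`) reads > 10000 nM, which is a limit. Compound 3 (`COc1cccc(-c2ncnn2-c2cc(OC)c(OC)c(OC)c2)c1`) reads > 10000 nM, also a limit.

Compound 4 (`CCOc1ccc(-c2ncnn2-c2cc(OC)c(OC)c(OC)c2)cc1`) changes compound 2 in one place: methyl in place of hydrogen on a saturated chain carbon bound to an oxygen on an aromatic ring. This is methyl in place of hydrogen on a saturated chain carbon bound to an oxygen on an aromatic ring, so methoxy becomes ethoxy.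

Among the measured compounds shown here, one measured step bears on this, the large at least 27-fold higher number from compound 2 to compound 3 (1.44 log units; beyond the scatter). That step exchanges 4-methoxyphenyl for 3-methoxyphenyl and leaves the methoxy group itself unchanged, so it shows how far compound 3 falls from compound 2 but does not measure the lengthening to ethoxy. For the measured compounds named here, no measured step covers that change.

Expected in this assay is a small step without a firm direction: a 1.1-fold higher number from compound 2 to compound 4 (0.05 log units; within the scatter). The estimate for compound 4 is 400 nM, with an expected range of 80 nM to 3000 nM.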

Compound 4, half-maximal inhibitory concentration: 50 nM
The estimate for compound 4 lay 8.0-fold (0.90 log units) above the measured number; measured number below the stated range.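

In this assay, methoxy becoming ethoxy gives a 7.2-fold lower number from compound 2 to compound 4 (0.86 log units; beyond the scatter), so a methyl in place of hydrogen on this saturated chain carbon bound to an oxygen on an aromatic ring is accepted, and the number falls beyond the scatter. Among these compounds, the earlier step to compound 3 exchanged 4-methoxyphenyl for 3-methoxyphenyl and left the methoxy group itself unchanged, so this is the first measured change to the group itself. Compound 4 also gives the series a second number to set against compound 2, where the other readings stop at a limit: the limit of > 10000 nM in this assay, at which 2 of the 4 values shown sit.

As far as these compounds go, whether the lower number continues with a longer chain such as propoxy, or holds with branched isopropoxy, stays open. Also open, from the compounds shown here alone, is how a hydroxy group or an amine would read in place of the ethoxy group.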